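Aryl amidine guanylhydrazones: butyl for hydroxy

The source may hold more compounds than are shown below. What is called first, only, known or untested is meant among the compounds shown, and "the series" means these compounds.

Measured so far:
compound 1 `C/C(=N\N=C(N)N)c1cccc(C(=N)N)c1`, 66 nM
compound 2 `N=C(NO)N/N=C/c1cccc(C(=N)N)c1`, 92 nM

In an assay for inhibition of S-adenosylmethionine decarboxylase proenzyme (Rattus norvegicus) (a lower number here means a stronger inhibitor, a higher number a weaker inhibitor), compound 1 gives 66 nM and compound 2 gives 92 nM; the two numbers lie within the usual scatter of each other, so neither stands apart. Compound 3 `CCCCNC(=N)N/N=C/c1cccc(C(=N)N)c1` is not yet measured. It differs from compound 2 by butyl in place of hydroxy on an amine nitrogen. Among the compounds with values here, no measured pair shows this change, so nothing is known of its effect. The step from compound 2 to compound 3 is expected to be a 2.0-fold higher number from compound 2 to compound 3 (0.29 log units; within the scatter), a modest weakening at most, possibly none beyond the scatter. Compound 3 is estimated at 180 nM, within 50 nM to 700 nM.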

Compound 3, half-maximal inhibitory concentration: 160 nM
The estimate for compound 3 lay 1.1-fold (0.05 log units) above the measured number; the range from low to high includes it.
By their numbers in this assay, from the lowest: compounds 1, 2 and 3 (each within the scatter of the next, the first and the last beyond it).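

On the amine nitrogen, butyl in place of hydroxy gives a 1.7-fold higher number from compound 2 to compound 3 (0.24 log units; within the scatter) in this assay and so stays within the scatter. This position therefore accepts a butyl chain, even with the hydrogen-bond donor and acceptor of the hydroxy group gone. No available measurement explains this result.

A single pair cannot show how far this holds. Still open, going by these compounds, are a longer chain, a benzyl group and a chain ending in an amine or a carboxylic acid on this nitrogen.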